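This account rests on a few compounds, and the source may have more. Where it says the series, first, only, none or still open, it means among the compounds named here.

In a functional assay on PC-3 cells (Homo sapiens) for antiproliferative activity, read by MTT assay, with a stated time of 48 h (a higher number here means a weaker inhibitor, a lower number a stronger inhibitor), three compounds share one core and one 2-phenylethenyl side chain and differ only in the aryl group on a nitrogen. Compound 1 `N#Cc1cccc(Nc2ncnc3cc(NC(=O)/C=C/c4ccccc4)sc23)c1` gives 540 nM, compound 2 `O=C(/C=C/c1ccccc1)Nc1cc2ncnc(Nc3ccc(F)c(Cl)c3)c2s1` gives 200 nM and compound 3 `O=C(/C=C/c1ccccc1)Nc1cc2ncnc(Nc3cc(Cl)cc(Cl)c3)c2s1` gives 220 nM. Compound 2 holds the low end of this short series together with compound 3, since the two lie within the scatter of each other (a 1.1-fold higher number from compound 2 to compound 3 (0.04 log units; within the scatter)). Compound 1 stands clearly apart, with a 2.7-fold lower number from compound 1 to compound 2 (0.43 log units; beyond the scatter) and a 2.5-fold lower number from compound 1 to compound 3 (0.39 log units; beyond the scatter).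

Compound 4 `COc1ccc(/C=C/C(=O)Nc2cc3ncnc(Nc4ccc(F)c(Cl)c4)c3s2)cc1` keeps the 3-chloro-4-fluorophenyl group of compound 2 and changes the other end of the molecule, from phenyl to 4-methoxyphenyl: methoxy in place of hydrogen on an aromatic carbon. This places methoxy in place of hydrogen on an aromatic carbon. Within the data shown here, none of the measured steps touches this ring, as all three exchange the aryl group on the nitrogen, so they offer no direct reading of the methoxy change. Among the measured compounds shown here, they show only that steps have so far been modest or smaller. On these data alone, no shift beyond the scatter is therefore expected, though a small move in either direction remains open. The expected change is a 1.2-fold higher number from compound 2 to compound 4 (0.06 log units; within the scatter). For compound 4 the estimated value is 230 nM, with an expected range from 90 nM to 600 nM.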

Compound 4, half-maximal inhibitory concentration: 100 nM
The estimate for compound 4 lay 2.3-fold (0.36 log units) above the measured number; low and high end bracket the measured number.
By their numbers in this assay, from the lowest: compounds 4, 2 and 3 (each within the scatter of the next, the first and the last beyond it); then compound 1.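

In this assay, methoxy in place of hydrogen on an aromatic carbon, para to a large group, gives a 2.0-fold lower number from compound 2 to compound 4 (0.30 log units; within the scatter), so the 2-(4-methoxyphenyl)ethenyl side chain of compound 4 cannot be told apart from the 2-phenylethenyl side chain of compound 2. Among these compounds, the earlier compounds differed only in the aryl group on the nitrogen, so this is the first reading at the other end of the molecule, and it shows that this ring can carry a methoxy group with no loss of antiproliferative activity beyond the scatter. No measurement shown here bears on what lies behind this result.

On these data alone, the reading rests on a single pair with the 3-chloro-4-fluorophenyl group, so it remains open whether methoxy would behave the same way on the 3-cyanophenyl group of compound 1 or the 3,5-dichlorophenyl group of compound 3. As far as these compounds go, it is also open whether a hydroxy group, a dimethylamino group, a carboxylic acid or a longer ether chain on the same carbon would separate from hydrogen in this assay.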